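Swapping an arylamine for pyrrolidine on a shared core

The source may hold more compounds than are shown below. What is called first, only, known or untested is meant among the compounds shown, and "the series" means these compounds.

Of the compounds shown here, two built on the same core have been measured in a functional assay on MGC-803 cells (Homo sapiens) for inhibition, read by sulforhodamine B assay; on this read-out higher numbers stand for weaker inhibition and lower numbers for stronger inhibition. Compound 1 `O=C1C(Nc2cccc(Cl)c2)=CC(=O)c2c1nc1n2[C@H]2OC[C@@H](O)[C@H]2OC1` gives 1530 nM in this assay. Compound 2 `Cc1ccc(NC2=CC(=O)c3c(nc4n3[C@H]3OC[C@@H](O)[C@H]3OC4)C2=O)cc1` gives 1550 nM. Among the compounds with values here, the one step between them, a 1.0-fold higher number from compound 1 to compound 2 (0.01 log units; within the scatter), shows that replacing one aryl group by another on the amine nitrogen left the number essentially where it was, so compound 2 sits alongside compound 1 with no difference beyond the scatter.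

Compound 3 `O=C1C(N2CCCC2)=CC(=O)c2c1nc1n2[C@H]2OC[C@@H](O)[C@H]2OC1` is not yet measured. It differs from compound 2 in one place: pyrrolidin-1-yl in place of (4-methylphenyl)amino on a double-bonded ring carbon. This change goes further than the measured step, since the anilino group is removed entirely rather than varied, and the hydrogen-bond donor disappears with it. Within the data shown here, no measured step covers such a replacement, so the only guide is the lack of movement seen from compound 1 to compound 2. On that basis a modest step is expected for a 1.6-fold higher number from compound 2 to compound 3 (0.21 log units; within the scatter), with the direction uncertain and a wide range allowed. Compound 3 is therefore estimated at 2500 nM in this assay, within 800 nM to 8000 nM.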

Compound 3, half-maximal inhibitory concentration: > 16000 nM
Compound 3: no number, only a limit (the forecaster's own chance of this, stated with the estimate: 5%); at least 6.4-fold (0.80 log units) between middle value and limit.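

Within the data shown here, the amine group on the double-bonded ring carbon matters far more than the earlier compounds suggested. Exchanging one aryl group for another there gave no difference beyond the scatter, but in this assay pyrrolidin-1-yl in place of (4-methylphenyl)amino gives an at least 10-fold higher number from compound 2 to compound 3 (1.01 log units; beyond the scatter), and the same ring in place of (3-chlorophenyl)amino gives an at least 10-fold higher number from compound 1 to compound 3 (1.01 log units; beyond the scatter). The value of compound 3 is a limit and not a number, so these steps give only a smallest size: the limit of > 16000 nM in this assay, at which 1 of the 3 values shown sits.

The change removes the aromatic ring and the hydrogen-bond donor together, and the compounds shown cannot tell which loss, or whether the combination, accounts for the large step. A cyclopentylamino group would keep the amine hydrogen on a non-aromatic ring, and a methyl(phenyl)amino group would keep the aromatic ring without that hydrogen, so this pair could separate the two features.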